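Three compounds at the limit, a fourth expected there too

A few compounds are considered here, and "the series" means these few. Any claim that something is new, unique, unknown or untested is made for them only; others in the source may bear on it.

Compound 1, `C=C1C[C@]23C[C@@]1(O)CC[C@H]2c1ccc(OS(=O)(=O)c2ccc(C)cc2)c(C)c1[C@@H]3Cn1cc(-c2ccc(Cl)cc2)nn1`: > 20000 nM in a functional assay on HL-60 cells (Homo sapiens) for cytotoxicity, read by MTT assay, with a stated time of 4 days; a higher number here means a weaker inhibitor, a lower number a stronger inhibitor.
Compound 2, `C=C1C[C@]23C[C@@]1(O)CC[C@H]2c1ccc(OS(=O)(=O)c2ccc(C)cc2)c(C)c1[C@@H]3Cn1cc(-c2ccc(C)cc2)nn1`: > 20000 nM in this assay.
Compound 3, `C=C1C[C@]23C[C@@]1(O)CC[C@H]2c1ccc(O)c(C)c1[C@@H]3Cn1cc(-c2ccc(OC)cc2)nn1`: > 20000 nM in this assay.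

Each of these three values is a limit of the assay and not a number. Compound 2 therefore stands only at a limit of this assay, and the two other values shown sit at the same limit, which is the limit of > 20000 nM in this assay, at which 3 of the 3 values shown sit. The step from compound 1 to compound 2 is a step that the two limits leave unreadable from compound 1 to compound 2, so its size cannot be read. Compound 4, `C=C1C[C@]23C[C@@]1(O)CC[C@H]2c1ccc(OS(=O)(=O)c2ccc(C)cc2)c(C)c1[C@@H]3Cn1cc(-c2ccccc2)nn1`, differs from compound 2 by hydrogen in place of methyl on an aromatic carbon. Among the measured compounds shown here, the only measured step that bears on this kind of change, from compound 1 to compound 2, is unreadable, and no value shown gives a number to work from. Compound 4 is therefore expected to stay at or near the limit in this assay, the expected step being a step that the limit leaves unreadable from compound 2 to compound 4, with no direction claimed beyond the scatter. The estimate for compound 4 in this assay is 30000 nM, within 12000 nM to 100000 nM, most likely again reported as a limit.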

Compound 4, half-maximal inhibitory concentration: > 20000 nM
Compound 4 ended at the assay's limit (the forecaster's own chance of this, stated with the estimate: 85%); the middle value does not contradict the limit.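

In this assay, among the compounds shown here, compound 4 gives > 20000 nM as a limit and not a number, and no step among compound 1, compound 2 and compound 4 can be read: the limit of > 20000 nM in this assay, at which 4 of the 4 values shown sit.

The compounds shown leave open whether chloro, methyl or hydrogen on that aromatic carbon makes any difference to cytotoxicity.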